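A few compounds are considered here, and "the series" means these few. Any claim that something is new, unique, unknown or untested is made for them only; others in the source may bear on it.

Measured so far in an ADME assay on microsomes from liver (Homo sapiens) for metabolic stability, read by LC-MS, with a stated time of 10 min, tested at 0.5 uM; a higher number here means that more of the compound is left, a lower number that less of the compound is left:
- compound 1 `c1ccc2c(c1)CN[C@@H](CN(CC[C@@H]1CCCNC1)[C@H]1CCCc3cccnc31)C2`: 75%
- compound 2 `c1cnc2c(c1)CCC[C@@H]2N(CCCN1CCNCC1)Cc1cc2ccccc2cn1`: 66%
- compound 3 `CN1CCN(CCCN(C[C@H]2Cc3ccccc3CN2C)[C@H]2CCCc3cccnc32)CC1`: 60%

Compound 1, at 75%, stands at the top of these three numbers, but compound 2, at 66%, lies within the scatter of it. Only compound 3, at 60%, lies lower than compound 1 by more than the scatter.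

The next compound, compound 4 `NC(=O)N1CCN(CCCN(C[C@H]2Cc3ccccc3CN2)[C@H]2CCCc3cccnc32)CC1`, has yet to be measured. Compared with compound 1, it carries (4-carbamoylpiperazin-1-yl)methyl in place of piperidin-3-yl on a saturated chain carbon, two bonds along the chain from an amine nitrogen.

Going by the values given here, no two measured compounds differ in one place only, so the data give no direct guide to the size of this step. Among the compounds with values here, the only guide is the narrow band of the three numbers, which runs down to compound 3 at 60%. With compound 1 at the top of that band, a small fall is expected rather than a further rise. In this assay, the expected change is a number 7 percentage points lower from compound 1 to compound 4 (within the scatter), a step that would stay within the scatter. The estimate for compound 4 is 68%, with an expected range of 53% to 82%.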

Compound 4, percent of the compound remaining: 79%
The estimate for compound 4 lay 11 percentage points below the measured number; low and high end bracket the measured number.
By their numbers in this assay, from the lowest: compounds 3, 2, 1 and 4 (each within the scatter of the next, the first and the last beyond it).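

In this assay, going by these compounds alone, the step reads a number 4 percentage points higher from compound 1 to compound 4 (within the scatter) and gives the first pair here that differs in one place only, with (4-carbamoylpiperazin-1-yl)methyl in place of piperidin-3-yl on a saturated chain carbon, two bonds along the chain from an amine nitrogen. The earlier compounds shown here could not show what a change at this place does, whereas this pair shows that the piperidin-3-yl group, with its defined stereocentre, can give way to a larger group holding a six-membered ring with two hetero atoms and a double bond outside aromatic rings, while the two numbers stay within the scatter of each other. No measurement at hand explains why the number holds across this change, so the pair records an outcome and gives no cause.

The compounds shown leave open which part of the entering group matters, as the ring, the carbamoyl group and the added methyl unit all come in with one step. They also cannot tell whether a morpholin-4-ylmethyl group or a carboxylic acid at this place would stay within the scatter of compound 1 in this assay as well.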